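The compounds below may be only part of what the source reports. "The series", "measured", "known", "first", "only" and "open" are said of these compounds alone.

Compound 1 `O=C1c2ccc(OCc3cccc(-c4ccccc4)c3)cc2CN1C1CCCC1` gives 95% in an ADME assay on a cell-free system (plasma, Rattus norvegicus) for metabolic stability, read by LC-MS, with a stated time of 1 h, at 37 degrees C, tested at 100 uM; a lower number here means that less of the compound is left, a higher number that more of the compound is left
Compound 2 `COc1ccc(-c2cccc(COc3ccc4c(c3)CN(C3CCCC3)C4=O)c2)cc1C(=O)O` gives 100% in this assay

Compound 2 stands at 100% and lies within the scatter of compound 1. Compound 3 `Cc1ccc(C(=O)O)cc1-c1cccc(COc2ccc3c(c2)CN(C2CCCC2)C3=O)c1` carries 5-carboxy-2-methylphenyl in place of 3-carboxy-4-methoxyphenyl on an aromatic carbon in the same place. Within the data shown here, the one measured step at that place is a number 5 percentage points higher from compound 1 to compound 2 (within the scatter) and it stays within the scatter. No step beyond the scatter is therefore expected in this assay for this change. The expected a number 4 percentage points lower from compound 2 to compound 3 (within the scatter) is small. Compound 3 is estimated at 96% with 85% to 104% as the expected range.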

Compound 3, percent of the compound remaining: 100%
For compound 3 the middle estimate is 4 percentage points below the measured one; the measured number falls inside the stated range.
By their numbers in this assay, from the lowest: compounds 1, 2 and 3 (each within the scatter of the next).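

In this assay, the change of 3-carboxy-4-methoxyphenyl to 5-carboxy-2-methylphenyl gives no change at the digits printed from compound 2 to compound 3 (within the scatter) and the change of phenyl to 5-carboxy-2-methylphenyl gives a number 5 percentage points higher from compound 1 to compound 3 (within the scatter) at this place. On this aromatic carbon, a second carboxy-bearing aryl group thus leaves the read-out within the scatter of both earlier compounds. No evidence on the cause of this result is available. From the compounds shown here alone, what remains open is whether an amine or a tetrazole on this ring would give a similar number in this assay. Going by these compounds, a group with a basic nitrogen or a longer chain carrying the carboxylic acid also remains untested in these compounds.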